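Propanoyl to (oxan-4-yl)carbonyl: what compound 4 may give

The compounds below may be only part of what the source reports. "The series", "measured", "known", "first", "only" and "open" are said of these compounds alone.

Within the data shown here, compound 3 `CCC(=O)N1CCc2nc(C#Cc3ccccc3)sc2C1` gives 38 nM in an assay on HEK293 cells for negative allosteric modulation of metabotropic glutamate receptor 5 (Homo sapiens), read by FLIPR, with a stated time of 1 h (on this read-out higher numbers stand for weaker inhibition and lower numbers for stronger inhibition), the only number among the three values shown. Compound 1 `O=C1NCCc2nc(C#Cc3cccc(F)c3)sc21` sits at > 10000 nM in this assay, which is a limit of the assay and not a number. Compound 2 `Cc1cccc(C#Cc2nc3c(s2)C(=O)NCC3)c1` likewise reaches only the limit > 10000 nM in this assay. The step that the two limits leave unreadable from compound 1 to compound 2 therefore has no readable size since both ends rest on (the limit of > 10000 nM in this assay, at which 2 of the 3 values shown sit). Compound 4 `O=C(C1CCOCC1)N1CCc2nc(C#Cc3ccccc3)sc2C1` differs from compound 3 by oxan-4-yl in place of ethyl on a carbonyl carbon. Among the measured compounds shown here, no measured step touches the carbonyl carbon, so nothing among the three compounds shows how large a change at that place is. For the measured compounds named here, with no bearing step, the expected change from compound 3 is a 1.1-fold higher number from compound 3 to compound 4 (0.02 log units; within the scatter), none beyond the scatter. Compound 4 is estimated at 40 nM, between 10 nM and 160 nM.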

Compound 4, half-maximal inhibitory concentration: > 10000 nM
Compound 4: only a limit was reported (the forecaster's own chance of this, stated with the estimate: 5%); middle value at least 250-fold (2.39 log units) away from the limit.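

Oxan-4-yl in place of ethyl on a carbonyl carbon gives an at least 260-fold higher number from compound 3 to compound 4 (2.42 log units; beyond the scatter), the only readable step so far, so a single change at this place can carry the read-out from a number to the limit. In this assay, on these data alone, compound 4 stands at a limit and not a number, so the full size of the step stays unknown: the limit of > 10000 nM in this assay, at which 3 of the 4 values shown sit.

Open, as far as these compounds go, is whether the ring or its oxygen drives the change; cyclohexyl on the same carbonyl carbon would separate the two. From the compounds shown here alone, a longer chain such as butanoyl also remains open.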